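Compound 3 measured against two limits

This account rests on a few compounds, and the source may have more. Where it says the series, first, only, none or still open, it means among the compounds named here.

compound 1 `COc1cc(-c2nn(-c3cccc(NC(=O)Nc4ccc(Cl)c(Cl)c4)c3)cc2-c2ccncc2)ccc1Cl` gives > 50000 nM as a limit
compound 2 `O=C(Nc1cccc(-n2cc(-c3ccncc3)c(-c3ccc(Cl)c(O)c3)n2)c1)Nc1ccc(Cl)c(Cl)c1` gives > 32500 nM as a limit
compound 3 `COc1cc(-c2nn(-c3cccc(NC(=O)c4ccc(Cl)c(C(F)(F)F)c4)c3)cc2-c2ccncc2)ccc1Cl` has no measurement yet

Going by these compounds, in a functional assay on K562 cells (Homo sapiens) for inhibition, read by sulforhodamine B assay, with a stated time of 48 h (a higher number here means a weaker inhibitor of growth, a lower number a stronger inhibitor of growth), compound 1 stands at > 50000 nM as a limit and not a number, so its exact place is unknown. Compound 2 stands at > 32500 nM as a limit too.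

Compound 3 keeps the core of compound 1 and differs from it in one place: 4-chloro-3-(trifluoromethyl)phenyl in place of (3,4-dichlorophenyl)amino on a carbonyl carbon.

Within the data shown here, the only measured step, a step that the two limits leave unreadable from compound 1 to compound 2, puts hydrogen in place of methyl on an oxygen on an aromatic ring. It is a different change, and it gives no readable size to carry over. No size or direction of change can therefore be drawn from the data, and no shift beyond the scatter is expected in this assay for compound 3.

The expected step, an at least 1.1-fold lower number from compound 1 to compound 3 (0.04 log units; that floor lies within the scatter), rests on compound 1 and its limit of > 50000 nM as the only anchor. For compound 3 the estimated value is 45000 nM, with an expected range from 15000 nM to 90000 nM, and the assay may again report only a limit.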

Compound 3, concentration for total growth inhibition: > 32500 nM
Compound 3 gave a limit, no number; the forecaster's own chance of this, stated with the estimate: 70%; the middle value does not contradict the limit.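

In this assay compound 3 gives > 32500 nM, which is a limit and not a number. Compound 1 likewise stands only at a limit, > 50000 nM. Among these compounds, no step from compound 1 to compound 3 can be read from these two limits. The compounds shown leave open whether 4-chloro-3-(trifluoromethyl)phenyl in place of (3,4-dichlorophenyl)amino shifts growth inhibition at all, and in which direction.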